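A few compounds are considered here, and "the series" means these few. Any claim that something is new, unique, unknown or untested is made for them only; others in the source may bear on it.

Working notes on the series. Among the compounds with values here, compound 2 `CC(/C=C/CC(C)CCCC(C)C)=C\C(=O)NCC(C)C` is the lower of the two numbers so far in a physicochemical assay for lipophilicity; a lower number here means a more polar compound, a higher number a more lipophilic compound: in this assay compound 2 gives 6.19, while compound 1 `C=CCSC(=O)/C=C(C)/C=C/CC(C)CCCC(C)C` gives 7.97. Within the data shown here, the only step is a number 1.78 log units lower from compound 1 to compound 2 (beyond the scatter), isobutylamino in place of allylsulfanyl on a carbonyl carbon, and it lies beyond the scatter.

The next compound, compound 3 `CC(/C=C/CC(C)CCCC(C)C)=C\C(=O)c1ccccc1`, is not yet measured. It differs from compound 2 by phenyl in place of isobutylamino on a carbonyl carbon. That step bears on the same carbonyl carbon as the measured step, and it removes the one hydrogen-bond donor counted for isobutylamino while bringing in a six-membered aromatic ring of carbon only. Given that compound 1 stands at 7.97 with no donor at that carbonyl, a large upward step in this assay is expected for compound 3, estimated at a number 1.41 log units higher from compound 2 to compound 3 (beyond the scatter). Compound 3 is therefore expected at 7.6, with a range of 6.9 to 8.3.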

Compound 3, partition coefficient: 7.26
Compound 3: middle estimate off by 0.34 log units, on the high side; the measured number falls inside the stated range.
By their numbers in this assay, from the lowest: compound 2; then compound 3; then compound 1.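

In this assay, putting phenyl on the carbonyl carbon gives a number 1.07 log units higher from compound 2 to compound 3 (beyond the scatter) when it replaces isobutylamino and a number 0.71 log units lower from compound 1 to compound 3 (beyond the scatter) when it replaces allylsulfanyl, which places phenyl between the other two groups. Removing the hydrogen-bond donor of isobutylamino therefore does not bring the number back to that of compound 1, and compound 1 and compound 3, neither with a donor at this carbon, still stand apart beyond the scatter. No measurement at hand accounts for this order of the three groups.

The compounds shown leave open where a saturated cyclohexyl ring or an allyloxy group on the same carbonyl carbon would fall among these three. They also leave open whether the order of the three groups holds on a shorter chain.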